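The source may hold more compounds than are shown below. What is called first, only, known or untested is meant among the compounds shown, and "the series" means these compounds.

Compound 1 `COc1cc(NC(C)CCCNC(=O)NNC(=O)Nc2ccc(O)cc2)c2ncccc2c1` gives 142000 nM in a functional assay on MIA PaCa-2 cells (Homo sapiens) for inhibition, read by MTT assay, with a stated time of 72 h (a higher number here means a weaker inhibitor, a lower number a stronger inhibitor), and compound 2 `COc1cc(NC(C)CCCNC(=O)NNC(=O)Nc2cccc(Cl)c2)c2ncccc2c1` gives 74000 nM in this assay. Compound 2 holds the lower of these two numbers, yet the step of a 1.9-fold lower number from compound 1 to compound 2 (0.28 log units; within the scatter) leaves it within the scatter of compound 1. Compound 3 `COc1cc(NC(C)CCCNC(=O)Nc2cccc(O)c2)c2ncccc2c1` differs from compound 2 in one place: 3-hydroxyphenyl in place of ((3-chlorophenyl)carbamoyl)amino on an amide-type nitrogen. Among the measured compounds shown here, no measured step touches this part of the structure; the only known step, a 1.9-fold lower number from compound 1 to compound 2 (0.28 log units; within the scatter), concerns a different part and stays within the scatter. With nothing comparable to lean on, the expected step of a 1.1-fold higher number from compound 2 to compound 3 (0.03 log units; within the scatter) is none beyond the scatter. Compound 3 is therefore estimated at 80000 nM, with a range from 25000 nM to 250000 nM.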

Compound 3, half-maximal inhibitory concentration: 46000 nM
Compound 3: middle estimate off by 1.7-fold (0.24 log units), on the high side; the measured number falls inside the stated range.
By their numbers in this assay, from the lowest: compounds 3, 2 and 1 (each within the scatter of the next, the first and the last beyond it).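

Replacing ((3-chlorophenyl)carbamoyl)amino on the amide-type nitrogen with 3-hydroxyphenyl gives a 1.6-fold lower number from compound 2 to compound 3 (0.21 log units; within the scatter), so in this assay this group can shrink from 11 heavy atoms to 7 with no change beyond the scatter. Against ((4-hydroxyphenyl)carbamoyl)amino, the same 3-hydroxyphenyl gives a 3.1-fold lower number from compound 1 to compound 3 (0.49 log units; beyond the scatter), the first step in this set to pass the scatter, though only modestly. No supporting measurement is available to explain either step.

Still open, as far as these compounds go, is how an amine or a carboxylic acid would fare in place of 3-hydroxyphenyl on that nitrogen.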